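Side-chain swaps at one position and cell cytotoxicity

The source may report more compounds than this note shows. Statements on the series, on what has been measured and on what is new or still open speak of the compounds shown alone.

Measured in an ADME assay on L02 cells (Homo sapiens) for cytotoxicity, read by MTT assay, with a stated time of 48 h; a higher number here means a weaker inhibitor, a lower number a stronger inhibitor:
compound 1 `CN(CCC#N)C[C@H]1CN(c2ccc(-n3cc(-c4ccccn4)cn3)c(F)c2)C(=O)O1`: > 400 ug/mL
compound 2 `CN1CCN(C[C@H]2CN(c3ccc(-n4cc(-c5ccccn5)cn4)c(F)c3)C(=O)O2)CC1`: 70 ug/mL
compound 3 `O=C1O[C@@H](CN2CCC(O)CC2)CN1c1ccc(-n2cc(-c3ccccn3)cn2)c(F)c1`: > 400 ug/mL

Compound 3 stands at the limit of this assay, not at a number. Compound 1 also reports only the limit, (the limit of > 400 ug/mL in this assay, at which 2 of the 3 values shown sit). Among the measured compounds shown here, compound 2 is the single member with a read number. For the measured compounds named here, the one step that leaves the limit is an at least 5.7-fold lower number from compound 1 to compound 2 (0.75 log units; beyond the scatter). The step back is an at least 5.7-fold higher number from compound 2 to compound 3 (0.75 log units; beyond the scatter). Between the two limits the step is a step that the two limits leave unreadable from compound 1 to compound 3.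

Compound 4 `O=C1CNC(=O)N1C[C@H]1CN(c2ccc(-n3cc(-c4ccccn4)cn3)c(F)c2)C(=O)O1` differs from compound 3 at the same position the other changes occupy: 2,5-dioxoimidazolidin-1-yl in place of 4-hydroxypiperidin-1-yl on a saturated chain carbon bound to a saturated ring carbon. Going by the values given here, no measured step exchanges a group of this kind, so none bears on it directly; the only step with a readable direction is the one from compound 1 to compound 2, and compound 3 already sits back at the limit. Compound 4 is therefore expected to stay at the limit as well, a step of a number no higher from compound 3 to compound 4 (the limit leaves the size open). The estimate for compound 4 in this assay is 400 ug/mL, with a range of 150 ug/mL to 800 ug/mL.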

Compound 4, half-maximal inhibitory concentration: > 400 ug/mL
Compound 4: only a limit was reported; the forecaster's own chance of this, stated with the estimate: 70%; the middle value lies on the limit itself.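

In this assay compound 4 gives > 400 ug/mL, which is a limit and not a number. The 2,5-dioxoimidazolidin-1-yl group shows that a five-membered non-aromatic ring on this saturated chain carbon also gives no read number, and the 4-methylpiperazin-1-yl group of compound 2 remains the one exception among the four side chains, with an at least 5.7-fold higher number from compound 2 to compound 4 (0.75 log units; beyond the scatter). The steps to compound 4 from compound 1 and from compound 3 cannot be read, and the series now stands as follows: the limit of > 400 ug/mL in this assay, at which 3 of the 4 values shown sit.

Still open, going by these compounds, is whether the read number of compound 2 depends on the whole 4-methylpiperazin-1-yl group or only on part of it; an unsubstituted piperazin-1-yl or a morpholin-4-yl group would separate these cases. No order can be set among compound 1, compound 3 and compound 4 at this limit.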